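The source may hold more compounds than are shown below. What is called first, only, known or untested is meant among the compounds shown, and "the series" means these compounds.

Compound 1, `COc1cc(/C(=C\c2cn(C(C)=O)c3ccc(OCc4ccccc4)cc23)C(=O)O)cc(OC)c1OC`: 950 nM
Compound 2, `COc1ccc(Cn2cc(/C=C(/C(=O)O)c3ccccc3)c3cc(OCc4ccccc4)ccc32)cc1`: 860 nM

Of the compounds shown here, two have been tested in a functional assay on DU-145 cells (Homo sapiens) for cytotoxicity, read by MTT assay, with a stated time of 72 h; a higher number here means a weaker inhibitor, a lower number a stronger inhibitor. Compound 1 gives 950 nM, the higher of the two numbers, while compound 2 gives 860 nM; the two differ so little that no order between them can be claimed, and their structures differ in more than one place, so no single change can be read from that pair.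

Compound 3, `CC(=O)n1cc(/C=C(/C(=O)O)c2ccc(Cl)cc2)c2cc(OCc3ccccc3)ccc21`, is the next compound to be measured in this assay. It differs from compound 1 in one place: 4-chlorophenyl in place of 3,4,5-trimethoxyphenyl on a double-bonded chain carbon bound to a carbonyl carbon and a double-bonded chain carbon. The benzyloxy group and the acetyl group on the shared core are kept.

Among the compounds with values here, no measured pair in this set tracks that change alone. Compound 2 carries a plain phenyl on the same chain carbon and lands close to compound 1, which suggests the aryl group at that position may tolerate change. On that basis the step from compound 1 to compound 3 is expected to be small, a 1.6-fold higher number from compound 1 to compound 3 (0.20 log units; within the scatter), possibly toward a weaker result, within or just beyond the scatter. Compound 3 is estimated at 1500 nM, with a range from 500 nM to 5000 nM.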

Compound 3, half-maximal inhibitory concentration: 1130 nM
The estimate for compound 3 lay 1.3-fold (0.12 log units) above the measured number; measured number inside the range.
By their numbers in this assay, from the lowest: compounds 2, 1 and 3 (each within the scatter of the next).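

In this assay, placing 4-chlorophenyl where 3,4,5-trimethoxyphenyl stood on a double-bonded chain carbon bound to a carbonyl carbon and a double-bonded chain carbon gives a 1.2-fold higher number from compound 1 to compound 3 (0.08 log units; within the scatter). Within the data shown here, this is the first reading of this position with everything else on the shared core held constant, and it shows no difference that can be told apart from the scatter, even though the group goes from 12 heavy atoms to 7 and from 3 hydrogen-bond acceptors to 0. The three methoxy groups are therefore not needed to keep the number in this range in this one assay, although no information is available on why these two aryl groups read alike.

On these data alone, it remains open whether the same holds for other groups on this chain carbon, such as a phenyl ring carrying a dimethylamino group or a nitrile. The compounds shown also leave open how the number would respond if the acetyl group were replaced by a longer chain such as butanoyl, or the carboxylic acid by a primary amide.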